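Swapping the Acyl Group on Compound 1 for Ethylsulfonyl

The source may report more compounds than this note shows. Statements on the series, on what has been measured and on what is new or still open speak of the compounds shown alone.

Compound 1 `Cc1ccncc1C(=O)N1CC(Oc2cncc(N3C(=O)c4ccc(Cl)cc4C3(C)C)c2)C1`: 10.4 mL/min/kg
Compound 2 `CCS(=O)(=O)N1CCC(c2cncc(N3C(=O)c4ccc(Cl)cc4C3(C)C)c2)CC1`: 35.1 mL/min/kg
Compound 3 `CC1(C)c2cc(Cl)ccc2C(=O)N1c1cncc(N2CCN(S(C)(=O)=O)CC2)c1`: 16.8 mL/min/kg

In an ADME assay on microsomes from liver (Rattus norvegicus) for metabolic stability, read by LC-MS, using NADPH, with stated times of 10 min and 30 min (a lower number here means slower removal, a higher number faster removal of the compound), compound 1 gives 10.4 mL/min/kg, within the scatter of compound 3 at 16.8 mL/min/kg. Compound 2 gives 35.1 mL/min/kg, a higher number than compound 1, beyond the scatter. The next compound is compound 4 `CCS(=O)(=O)N1CC(Oc2cncc(N3C(=O)c4ccc(Cl)cc4C3(C)C)c2)C1`, with ethylsulfonyl in place of (4-methylpyridin-3-yl)carbonyl on an amine nitrogen in a ring. Among the measured compounds shown here, no measured pair isolates this change. Only compound 2 35.1 mL/min/kg shares ethylsulfonyl with compound 4, and it differs elsewhere too. A modest upward move, not beyond the scatter, is therefore expected in this assay: a 1.7-fold higher number from compound 1 to compound 4 (0.24 log units; within the scatter). The estimated clearance of compound 4 is 18 mL/min/kg, with an expected range of 9 mL/min/kg to 36 mL/min/kg.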

Compound 4, clearance: 5 mL/min/kg
Compound 4: middle estimate off by 3.6-fold (0.56 log units), on the high side, and the stated range ends above it.
By their numbers in this assay, from the lowest: compound 4; then compounds 1 and 3 (each within the scatter of the next); then compound 2.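

In this assay, among the compounds shown here, ethylsulfonyl in place of (4-methylpyridin-3-yl)carbonyl on an amine nitrogen in a ring gives a 2.1-fold lower number from compound 1 to compound 4 (0.32 log units; beyond the scatter) as the first step in this set that changes one place only. At this nitrogen of the four-membered ring, then, the aromatic ring of the acyl group is not required for a low number. No measurement shown here accounts for this step.

Going by these compounds, whether a longer sulfonyl chain such as propylsulfonyl would keep the number this low remains open. So does whether a small acyl group such as acetyl would behave like ethylsulfonyl at this nitrogen.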